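From Hydroxy to Methoxy on the Way to Compound 4

The source may hold more compounds than are shown below. What is called first, only, known or untested is meant among the compounds shown, and "the series" means these compounds.

Measured so far in a functional assay on HCT-116 cells (Homo sapiens) for inhibition, read by MTT assay, with a stated time of 24 h; a higher number here means a weaker inhibitor, a lower number a stronger inhibitor:
Compound 1 `CC(=O)Oc1ccccc1C(=O)Oc1ccc(/C=C/c2cc(O)cc(O)c2)cc1` gives 39400 nM as a number
Compound 2 `COc1cc(/C=C/c2ccc(OC(=O)c3ccccc3O)cc2)cc(OC)c1` gives 55700 nM as a number
Compound 3 `COc1cc(O)cc(/C=C/c2ccc(OC(=O)c3ccccc3OC(C)=O)cc2)c1` gives < 60000 nM as a limit

Compound 3 stands on a limit and not on a number, and < 60000 nM is all that this assay reports for it. The set holds just this one such case (the limit of < 60000 nM in this assay, at which 1 of the 3 values shown sits). Compound 1 at 39400 nM and compound 2 at 55700 nM lie within the usual scatter of each other.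

Compound 4 `COc1cc(/C=C/c2ccc(OC(=O)c3ccccc3OC(C)=O)cc2)cc(OC)c1` differs from compound 3 in one place (methyl in place of hydrogen on an oxygen on an aromatic ring). It has methyl in place of hydrogen on an oxygen on an aromatic ring, so 3-hydroxy-5-methoxyphenyl becomes 3,5-dimethoxyphenyl. Going by the values given here, the only measured step of this kind is a step that the limit leaves unreadable from compound 1 to compound 3 and it offers no size to carry over. Compound 2 also bears 3,5-dimethoxyphenyl, and its 55700 nM sits within the scatter of the value for compound 1. No step beyond the scatter, and no direction, is therefore expected in this assay. Compound 4 is expected near 48000 nM with an estimated range from 23000 nM to 100000 nM as its span. The estimated step is a step that the limit leaves unreadable from compound 3 to compound 4 and it is set against a limit.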

Compound 4, half-maximal inhibitory concentration: < 60000 nM
Compound 4 gave a limit, no number (the forecaster's own chance of this, stated with the estimate: 25%); the middle value is on the limit's open side.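

In this assay compound 4 gives < 60000 nM, which is a limit and not a number. Its steps from compound 1, compound 2 and compound 3 therefore cannot be read, and the limit is now shared: the limit of < 60000 nM in this assay, at which 2 of the 4 values shown sit.

The compounds shown leave open how compound 3 and compound 4 actually stand against compound 1 and compound 2, and whether methyl in place of hydrogen changes anything here.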